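The source may hold more compounds than are shown below. What is called first, only, known or untested is meant among the compounds shown, and "the series" means these compounds.

Measured compounds in a functional assay on HL-60 cells (Homo sapiens) for inhibition, read by MTT assay, with a stated time of 48 h; a lower number here means a stronger inhibitor, a higher number a weaker inhibitor:
Compound 1, `Cc1cc2c(cc1C(=O)c1ccc(C(=O)NCCCCCCNC(=O)c3ccc(C(=O)Nc4ccc5c(c4)C(C)(C)CCC5(C)C)cc3)cc1)C(C)(C)CCC2(C)C`, gives 95400 nM.
Compound 2, `C=C(c1ccc(C(=O)OCCOC(=O)c2ccc(C(=O)Nc3ccc4c(c3)C(C)(C)CCC4(C)C)cc2)cc1)c1cc2c(cc1C)C(C)(C)CCC2(C)C`, gives 30700 nM.
Compound 3, `CCCC(CCC)C(=O)OCCCOC(=O)c1ccc(C(=O)Nc2ccc3c(c2)C(C)(C)CCC3(C)C)cc1`, gives 835000 nM.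

Of these three numbers in this assay, compound 3 stands highest, and so weakest. Its nearest neighbour is compound 1, whose lower number lies beyond the usual scatter; compound 2 lies further still, also beyond the scatter. Compound 3 thus sits apart from the other two, and it is the only one of the three without a second core attached through the linker.

Compound 4, `CCCC(=O)OCCCOC(=O)c1ccc(C(=O)Nc2ccc3c(c2)C(C)(C)CCC3(C)C)cc1`, is the next compound to be measured. It differs from compound 3 in one place: propyl in place of 1-propylbutyl on a carbonyl carbon. Among the compounds with values here, nothing among the measured compounds shows how such a shortening of the chain on this carbonyl carbon plays out, since no pair of measured compounds differs in this way alone, and the shared core and ester-bearing chain are untouched. In the absence of such guidance, the step from compound 3 to compound 4 in this assay is expected to stay within the scatter, a 1.1-fold higher number from compound 3 to compound 4 (0.03 log units; within the scatter), with no clear direction. Compound 4 is therefore estimated at 900000 nM, within a range from 300000 nM to 2700000 nM.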

Compound 4, half-maximal inhibitory concentration: 2990 nM
Compound 4: the middle estimate sits 300-fold (2.48 log units) above what was measured, and the stated range ends above it.
By their numbers in this assay, from the lowest: compound 4; then compound 2; then compound 1; then compound 3.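

In this assay, within the data shown here, putting propyl in place of 1-propylbutyl on the carbonyl carbon gives a 280-fold lower number from compound 3 to compound 4 (2.45 log units; beyond the scatter) and so shows that this position, for which the earlier compounds offered no comparison, responds very strongly to the group it carries. The change only shortens an all-carbon group, with no ring, hydrogen-bond donor, hydrogen-bond acceptor or net charge entering or leaving, so a difference in carbon chain alone at this one place is enough for a step of this size. Nothing available bears on why the step is so large.

This single pair cannot separate the branching of the group from its length. It also leaves open how a methyl, an unbranched pentyl chain, an amine or a carboxylic acid at this position would read in this assay on the same core and linker.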